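Swapping the bromophenyl arm for a thiophene ring

The compounds below may be only part of what the source reports. "The series", "measured", "known", "first", "only" and "open" are said of these compounds alone.

Compound 1 `S=C(Nc1ccccc1)N1N=C(c2ccc(Br)cc2)CC1c1ccc2c(c1)OCCO2` is the strongest of three related compounds in a functional assay on HT-29 cells (Homo sapiens) for antiproliferative activity, read by MTT assay, with a stated time of 48 h; on this read-out higher numbers stand for weaker inhibition of growth and lower numbers for stronger inhibition of growth: compound 1 gives 2580 nM, while compound 2 `S=C(Nc1ccccc1)N1N=C(c2ccc(Cl)c(Cl)c2)CC1c1ccc2c(c1)OCCO2` gives 95300 nM and compound 3 `Cc1ccc(C2=NN(C(=S)Nc3ccccc3)C(c3ccc4c(c3)OCCO4)C2)cc1C` gives 133000 nM. Compound 4 `S=C(Nc1ccccc1)N1N=C(c2cccs2)CC1c1ccc2c(c1)OCCO2` differs from compound 1 in one place: thiophen-2-yl in place of 4-bromophenyl on a carbon with a double bond to nitrogen. For the measured compounds named here, no measured step changes the ring at that carbon in this way, but both changes made there so far were large and unfavourable, a 37-fold higher number from compound 1 to compound 2 (1.57 log units; beyond the scatter) and a 52-fold higher number from compound 1 to compound 3 (1.71 log units; beyond the scatter). The group at this position therefore clearly matters, and compound 4 is expected to fall somewhat weaker than compound 1, as a 4.7-fold higher number from compound 1 to compound 4 (0.67 log units; beyond the scatter). The estimate for compound 4 is 12000 nM, within a range from 2500 nM to 60000 nM.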

Compound 4, concentration for 50% growth inhibition: 188000 nM
For compound 4 the middle estimate is 16-fold (1.19 log units) below the measured one; measured number above the stated range.
By their numbers in this assay, from the lowest: compound 1; then compounds 2, 3 and 4 (each within the scatter of the next).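

Thiophen-2-yl does not keep the activity of 4-bromophenyl: the change is large (a 73-fold higher number from compound 1 to compound 4 (1.86 log units; beyond the scatter)). The new compound also lies level with the other two (a 1.4-fold higher number from compound 3 to compound 4 (0.15 log units; within the scatter); a 2.0-fold higher number from compound 2 to compound 4 (0.30 log units; within the scatter)), so among these four compounds, three quite different groups all sit far from compound 1, including one with a five-membered ring. Nothing measured here explains why the 4-bromophenyl group stands apart.

Open, on these data alone, is whether the bromine itself matters, which a phenyl group without bromine could test. So is whether an amine or a carboxylic acid on that ring would be tolerated.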